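Hydroxymethylphenyl head in place of isopropylphenyl

The compounds below may be only part of what the source reports. "The series", "measured", "known", "first", "only" and "open" are said of these compounds alone.

Of the compounds shown here, two have numbers so far. Compound 1 `CCOc1cc(C)c(-c2cccc(CNc3ccc(OCC(=O)O)cc3)c2)c(C)c1` gives 197 nM in a functional assay on CHO cells for agonist activity at Free fatty acid receptor 1 (Homo sapiens), read by FLIPR and calcium flux; on this read-out higher numbers stand for an effect only at larger amounts of compound and lower numbers for an effect already at smaller amounts. Compound 2 `CC(C)c1ccccc1-c1cccc(CNc2ccc(OCC(=O)O)c(F)c2)c1` gives 86.2 nM in this assay, the lowest of the two numbers and set apart from compound 1 by a gap beyond the usual scatter. Compound 3 `Cc1cc(O)ccc1-c1cccc(CNc2ccc(OCC(=O)O)c(F)c2)c1` is not yet measured. It differs from compound 2 in one place: 4-hydroxy-2-methylphenyl in place of 2-isopropylphenyl on an aromatic carbon, on an aromatic carbon meta to a large group. Among the compounds with values here, no pair of measured compounds shows this change, so no step for it is known. The expected step of a 2.3-fold higher number from compound 2 to compound 3 (0.37 log units; beyond the scatter) points toward a higher number in this assay, a modest loss that may well lie beyond the scatter. For compound 3 the estimate in this assay is 200 nM, with a range from 70 nM to 600 nM.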

Compound 3, half-maximal effective concentration: 69.6 nM
For compound 3 the middle estimate is 2.9-fold (0.46 log units) above the measured one, and the stated range ends above it.
By their numbers in this assay, from the lowest: compounds 3 and 2 (each within the scatter of the next); then compound 1.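

In this assay, the exchange of 2-isopropylphenyl for 4-hydroxy-2-methylphenyl gives a 1.2-fold lower number from compound 2 to compound 3 (0.09 log units; within the scatter), so the two heads cannot be told apart on this read-out. Within the data shown here, this aromatic carbon of the shared core therefore tolerates a head carrying a hydrogen-bond donor and acceptor as well as one carrying neither, a point the earlier compounds could not show. Nothing available explains why the two heads read alike.

From the compounds shown here alone, the change alters two features at once, so the separate contributions of the hydroxy group and of the methyl in place of isopropyl remain open. Also open, going by these compounds, is whether an amine or a carboxylic acid in place of the hydroxy group would keep the number in the same range.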